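Adding a sugar-like group to a benzimidazole nitrogen

The compounds below may be only part of what the source reports. "The series", "measured", "known", "first", "only" and "open" are said of these compounds alone.

Compound 1 `COc1ccnc(CNc2ccc3c(c2)nc(C)n3C[C@@H](O)[C@H]2O[C@H](O)[C@@H](O)[C@H]2O)c1C`: 53%
Compound 2 `COc1c(C)cnc(CNc2ccc3[nH]c(C)nc3c2)c1C`: 49%

Both compounds were tested in a functional assay on the whole organism (strain Sprague-Dawley) for inhibition, with Rattus norvegicus as the target, read by paw edema, with a stated time of 180 min, at a dose of 20 mg/kg by the oral route; a lower number here means a weaker effect, a higher number a stronger effect of the compound at the dose given. Compound 2 gives the lower of the two numbers, but compound 1 sits only a little above it, within the usual scatter, so the two values show no real difference.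

Compound 3 `COc1c(C)cnc(CNc2ccc3c(c2)nc(C)n3C[C@@H](O)[C@H]2O[C@H](O)[C@@H](O)[C@H]2O)c1C` is built from compound 2 by one change: a group of 11 heavy atoms (6 carbon, 5 oxygen; one five-membered non-aromatic ring with 1 hetero atom) in place of a hydrogen atom, on an aromatic nitrogen. Compound 1 already carries the same group on a closely related core and gives 53%, so a step of no size beyond the scatter is expected from compound 2 to compound 3, that is a number 2 percentage points higher from compound 2 to compound 3 (within the scatter). Compound 3 is therefore estimated to reach 51%, with a range from 36% to 66%.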

Compound 3, a percentage reported as inhibition, in the whole organism at one dose (the size of the read-out at that dose, not a potency): 50%
Beside the measured number, compound 3's estimate is 1 percentage points above it, and the stated range covers the measured number.
By their numbers in this assay, from the lowest: compounds 2, 3 and 1 (each within the scatter of the next).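

In this assay the sugar-like group on the aromatic nitrogen brings a number 1 percentage points higher from compound 2 to compound 3 (within the scatter) and so shows that this position accepts a group of this size without a visible loss of effect at this dose. Methyl in place of hydrogen on an aromatic carbon brings a number 3 percentage points lower from compound 1 to compound 3 (within the scatter) and likewise leaves no clear mark on the read-out. Nothing measured here explains these results.

Still open, going by these compounds, is whether a different group on this nitrogen, such as a simple ethyl chain, an amine or a carboxylic acid, would move the number beyond the scatter.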